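The source may hold more compounds than are shown below. What is called first, only, known or untested is meant among the compounds shown, and "the series" means these compounds.

Measured so far in a functional assay on HepG2 cells (Homo sapiens) for inhibition, read by CCK-8 assay, with a stated time of 48 h; on this read-out higher numbers stand for weaker inhibition and lower numbers for stronger inhibition:
compound 1 `O=C1CSC(N2N=C(c3ccc(Br)cc3)CC2c2cccc3ccccc23)=N1` gives 13400 nM
compound 2 `COc1ccc(C2=NN(C3=NC(=O)CS3)C(c3cccc4ccccc34)C2)cc1` gives 7850 nM
compound 3 `O=C1CSC(N2N=C(c3ccc(Cl)cc3)CC2c2cccc3ccccc23)=N1` gives 16500 nM

Compound 2 has the lowest of the three numbers; a 1.7-fold lower number from compound 1 to compound 2 (0.23 log units; within the scatter) stays within the scatter, while a 2.1-fold higher number from compound 2 to compound 3 (0.32 log units; beyond the scatter) lies beyond it, and a 1.2-fold higher number from compound 1 to compound 3 (0.09 log units; within the scatter) is also within the scatter. Compound 4 `COc1ccc(C2=NN(C3=NC(c4ccccc4)CS3)C(c3cccc4ccccc34)C2)cc1` has not been measured. It differs from compound 2 by a group of 11 heavy atoms (9 carbon, 1 nitrogen, 1 sulfur; one five-membered non-aromatic ring with 2 hetero atoms, one six-membered aromatic ring of carbon only) in place of a group of 6 heavy atoms (3 carbon, 1 nitrogen, 1 oxygen, 1 sulfur; one five-membered non-aromatic ring with 2 hetero atoms), on an amine nitrogen in a ring. For the measured compounds named here, every measured step exchanges one group on an aromatic carbon and none alters the amine nitrogen in the ring, so no measured step bears on this change. A step no larger than the scatter is therefore expected in this assay, namely a 1.1-fold higher number from compound 2 to compound 4 (0.06 log units; within the scatter), with a wide range. Compound 4 is estimated to give 9000 nM, between 3000 nM and 30000 nM.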

Compound 4, half-maximal inhibitory concentration: 8740 nM
Compound 4: the middle estimate sits 1.0-fold (0.01 log units) above what was measured; measured number inside the range.
By their numbers in this assay, from the lowest: compounds 2, 4, 1 and 3 (each within the scatter of the next, the first and the last beyond it).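

The first step measured at the amine nitrogen in a ring is a 1.1-fold higher number from compound 2 to compound 4 (0.05 log units; within the scatter) in this assay. At this position, then, the group of 11 heavy atoms, with its six-membered aromatic ring of carbon only, gives a number close to that of the group of 6 heavy atoms, which carries a carbonyl. Nothing shown explains this closeness. Going by these compounds, the carbonyl and the aromatic ring change together here, so their separate contributions remain open. Also open, on these data alone, is how an amine or a carboxylic acid on that aromatic ring would read.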